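The source may report more compounds than this note shows. Statements on the series, on what has been measured and on what is new or still open speak of the compounds shown alone.

Measured compounds in a functional assay on the whole organism (strain Wistar) for inhibition, with Rattus norvegicus as the target, read by paw edema, with stated times of 60 min and 4 h, at a dose of 100 mg/kg by the oral route; a lower number here means less inhibition, a higher number more inhibition at the dose given (going by the name of the read-out):
- compound 1 `CCNC(=O)CC1CCc2cc(OC)c(OC)cc21`: 26.6%
- compound 2 `COc1cc2c(cc1OC)C(CC(=O)NC(C)C)CC2`: 39.1%
- compound 3 `COc1cc2c(cc1OC)C(CC(=O)NC(C)(C)C)CC2`: 32.8%

Compound 2 holds the highest of the three numbers. Its gap to compound 3 is small, a number 6.3 percentage points lower from compound 2 to compound 3 (within the scatter), so the two cannot be ordered; its gap to compound 1 is larger, a number 12.5 percentage points higher from compound 1 to compound 2 (beyond the scatter), and stands beyond the scatter.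

The next compound, compound 4 `COc1cc2c(cc1OC)C(CC(=O)NC1CCCC1)CC2`, differs from compound 2 in one place:
cyclopentyl in place of isopropyl on an amide-type nitrogen

For the measured compounds named here, three measured steps bear on this change, all of them alterations of the group on the amide-type nitrogen. Ethyl to isopropyl gave a number 12.5 percentage points higher from compound 1 to compound 2 (beyond the scatter), a modest rise. Ethyl to tert-butyl gave a number 6.2 percentage points higher from compound 1 to compound 3 (within the scatter), within the scatter. Isopropyl to tert-butyl gave a number 6.3 percentage points lower from compound 2 to compound 3 (within the scatter), also within the scatter. Enlarging the group on this nitrogen has therefore produced at most a modest movement, and between the two larger groups none beyond the scatter. Going from isopropyl to cyclopentyl is taken to behave like the latter two steps.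

The expected step is a number 2.1 percentage points lower from compound 2 to compound 4 (within the scatter), which is estimated to lie within the scatter. Compound 4 is accordingly expected to give about 37%, with a range from 25% to 50%.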

Compound 4, a percentage reported as inhibition, in the whole organism at one dose (the size of the read-out at that dose, not a potency): 45.3%
Compound 4: the middle estimate sits 8.3 percentage points below what was measured; the measured number falls inside the stated range.
By their numbers in this assay, from the lowest: compounds 1, 3, 2 and 4 (each within the scatter of the next, the first and the last beyond it).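

In this assay, for the compounds shown here, cyclopentyl brings a ring onto the amide-type nitrogen for the first time, and the change from isopropyl gives a number 6.2 percentage points higher from compound 2 to compound 4 (within the scatter), so a five-membered carbon ring and the open isopropyl group cannot be told apart at this position. Cyclopentyl does separate from the other two groups, where isopropyl separated only from ethyl: the change from tert-butyl gives a number 12.5 percentage points higher from compound 3 to compound 4 (beyond the scatter), and the change from ethyl gives a number 18.7 percentage points higher from compound 1 to compound 4 (beyond the scatter), the widest step among these compounds. No measurement shown here bears on what lies behind these differences.

The compounds leave open whether the ring itself or only the number of carbons matters, which a cyclobutyl, a cyclohexyl or an open pentyl chain on the same nitrogen would help to settle. Also open, as far as these compounds go, is how a ring holding an oxygen, such as tetrahydropyranyl, or an aromatic phenyl ring would compare, and the single-dose numbers give the size of the effect at that dose, not a potency.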